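Extending the Sulfonamide Nitrogen of Compound 2

A few compounds are considered here, and "the series" means these few. Any claim that something is new, unique, unknown or untested is made for them only; others in the source may bear on it.

Three measured compounds share one core and differ only in the group on the sulfonyl sulfur. Compound 1 `CC1(C)C=C(n2ccccc2=O)c2cc(S(=O)(=O)N=[N+]=[N-])ccc2O1` carries an azido group, and in a functional assay on the whole organism (aorta) with Rattus norvegicus as the target (a higher number here means a larger maximal response, a lower number a smaller maximal response), compound 1 reaches 88.3%. Compound 2 `CC1(C)C=C(n2ccccc2=O)c2cc(S(N)(=O)=O)ccc2O1` carries a plain amino group there; in this assay compound 2 reaches 77.5%, the second highest of the three numbers, with a step of a number 10.8 percentage points lower from compound 1 to compound 2 (beyond the scatter). Compound 3 `CN(c1ccccc1)S(=O)(=O)c1ccc2c(c1)C(n1ccccc1=O)=CC(C)(C)O2` carries a methyl(phenyl)amino group, and in this assay compound 3 reaches 64.2%, giving a number 13.3 percentage points lower from compound 2 to compound 3 (beyond the scatter), while a number 24.1 percentage points lower from compound 1 to compound 3 (beyond the scatter) points the same way.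

Compound 4 `CC1(C)C=C(n2ccccc2=O)c2cc(S(=O)(=O)NC(=O)Nc3ccccc3)ccc2O1` has not yet been measured. It differs from compound 2 by phenylcarbamoyl in place of hydrogen on a sulfonamide nitrogen. Among the compounds with values here, the closest precedent is a number 13.3 percentage points lower from compound 2 to compound 3 (beyond the scatter), where a larger, phenyl-bearing group entered at the sulfonyl sulfur and the response fell modestly. A similar modest fall is expected here. Compound 4 is therefore estimated to reach 65%, within a range of 50% to 80%. The expected step of a number 12.5 percentage points lower from compound 2 to compound 4 (beyond the scatter) should lie beyond the scatter, though not far beyond it.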

Compound 4, largest response reached (Emax), in percent of the reference or control that the assay uses: 90.8%
Estimate against measurement, compound 4: 25.8 percentage points below; measured number outside the range, above it.
By their numbers in this assay, from the lowest: compound 3; then compound 2; then compounds 1 and 4 (each within the scatter of the next).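

A phenyl ring on the group at the sulfonyl sulfur does not by itself bring a lower number in this assay: phenylcarbamoyl in place of hydrogen on the sulfonamide nitrogen gives a rise (a number 13.3 percentage points higher from compound 2 to compound 4 (beyond the scatter)). Compound 3 and compound 4 both carry a phenyl ring, yet they lie far apart (a number 26.6 percentage points higher from compound 3 to compound 4 (beyond the scatter)), so what links the ring to the sulfonyl sulfur matters at this position, at least among these compounds. The azido group and the (phenylcarbamoyl)amino group give numbers that cannot be told apart (a number 2.5 percentage points higher from compound 1 to compound 4 (within the scatter)), so the much larger group costs nothing in maximal response here.

Nothing given here explains the difference between the two phenyl-bearing groups. As far as these compounds go, whether the rise needs the phenyl ring or only the carbamoyl part stays open, and a methylcarbamoyl or acetyl group on the same nitrogen would bear on that question.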